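Fluoro for Chloro on a Thiophene-Linked Amidine Core

This account rests on a few compounds, and the source may have more. Where it says the series, first, only, none or still open, it means among the compounds named here.

Measured compounds:
Compound 1, `N=C(N)c1ccc(-c2ccc(-c3ccc(F)cc3)o2)o1`, 940 nM
Compound 2, `N=C(N)c1ccc(-c2ccc(-c3ccc(Cl)cc3)o2)o1`, 1700 nM
Compound 3, `N=C(N)c1ccc(-c2ccc(-c3ccc(Cl)cc3)s2)s1`, 1740 nM

These three compounds were tested in a functional assay on SW-620 cells (Homo sapiens) for inhibition, read by sulforhodamine B assay, with a stated time of 48 h; a lower number here means a stronger inhibitor of growth, a higher number a weaker inhibitor of growth. Compound 1 and compound 2 share one core, and compound 3 has a different core; how the two cores differ is not broken down here. Compound 2 and compound 1 differ by fluoro in place of chloro on an aromatic carbon, and this gave a 1.8-fold lower number from compound 2 to compound 1 (0.26 log units; within the scatter). The values of compound 2 and compound 3 lie within the scatter of each other.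

Compound 4, `N=C(N)c1ccc(-c2ccc(-c3ccc(F)cc3)s2)s1`, has not yet been measured. Compound 3 and compound 4 differ by fluoro in place of chloro on an aromatic carbon, the same change. For compound 4 the expected step is a 1.7-fold lower number from compound 3 to compound 4 (0.24 log units; within the scatter), resting on the step from compound 2 to compound 1, which was a 1.8-fold lower number from compound 2 to compound 1 (0.26 log units; within the scatter). Compound 4 is therefore estimated at 1000 nM, within 450 nM to 2200 nM.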

Compound 4, concentration for 50% growth inhibition: 1740 nM
The estimate for compound 4 lay 1.7-fold (0.24 log units) below the measured number; the measured number falls inside the stated range.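

In this assay, putting fluoro in place of chloro on the core of compound 3 gave no change at the digits printed from compound 3 to compound 4 (within the scatter). Set beside the same change on the other core, the two steps do not differ beyond what repeat measurements would produce: the same change on two cores in this assay, a 1.8-fold lower number (0.26 log units; within the scatter) from compound 2 to compound 1 and no change at the digits printed (within the scatter) from compound 3 to compound 4, 1.8-fold (0.26 log units) apart, within the scatter of two such steps This shows that the change behaves alike on these two cores, in that it moves the number by no more than the scatter on either, but it does not show that fluoro truly improves growth inhibition on either core, or that the agreement would hold on a third core.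

The compounds shown leave open what an amine, a methoxy group or a carboxylic acid would do on the same aromatic carbon. On these data alone, whether the two cores would still match with such a group there also stays open.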